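The source may report more compounds than this note shows. Statements on the series, on what has been measured and on what is new or still open speak of the compounds shown alone.

Measured so far:
compound 1 `Nc1ccccc1NC(=O)/C=C/c1ccc(Cn2cnc3c(Nc4ccccc4)nc(Cl)nc32)cc1` — 16.4%
compound 2 `Nc1ccccc1NC(=O)c1ccc(Cn2cnc3c(Nc4ccccc4)nc(Cl)nc32)cc1` — 49.6%
compound 3 `CCCCn1cnc2c(Nc3cccc(Cl)c3)nc(NCOCc3ccc(/C=C/C(=O)Nc4ccccc4N)cc3)nc21` — 20.5%

In a functional assay on HepG2 cells (Homo sapiens) for antiproliferative activity, read by CCK-8 assay, with a stated time of 72 h, tested at 2 uM (a higher number here means a stronger effect of the compound at the concentration tested, a lower number a weaker effect), compound 1 gives 16.4%, the lowest of the three numbers. Compound 3 stands nearest to it, within the scatter, while compound 2 stands furthest from it. Within the data shown here, the only step between two compounds that differ in one place is the one from compound 1 to compound 2, a number 33.2 percentage points higher from compound 1 to compound 2 (beyond the scatter), a large step obtained by replacing the ethenyl-linked amide with the amide attached directly to the ring.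

Compound 4 `Nc1ccccc1NC(=O)/C=C/c1ccc(Cn2cnc3c(Nc4cccc(OC(F)(F)F)c4)nc(Cl)nc32)cc1` differs from compound 1 by trifluoromethoxy in place of hydrogen on an aromatic carbon. Among the measured compounds shown here, none of the measured steps bears on this change: the step from compound 1 to compound 2 alters a different part of the molecule, and compound 3 differs from compound 1 in several places at once, so its value cannot be read as the effect of one substituent on the anilino ring. For the measured compounds named here, with no comparable step in hand, the expected step from compound 1 to compound 4 is small, a number 5.6 percentage points higher from compound 1 to compound 4 (within the scatter), and could lie in either direction within the scatter. Compound 4 is therefore expected to give about 22% in this assay, with a range from 8% to 45%.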

Compound 4, a percentage reported as inhibition, at one concentration (the size of the read-out at that concentration, not a potency): 16.2%
Compound 4: middle estimate off by 5.8 percentage points, on the high side; measured number inside the range.
By their numbers in this assay, from the lowest: compounds 4, 1 and 3 (each within the scatter of the next); then compound 2.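

Placing trifluoromethoxy on an aromatic carbon of the anilino ring, meta to a large group, gives a number 0.2 percentage points lower from compound 1 to compound 4 (within the scatter) in this assay, so the two compounds cannot be told apart at the concentration tested. Among these compounds, this is the first reading at this position, and it shows that a group of five heavy atoms can stand in place of hydrogen there with no readable difference in this read-out, at least while the ethenyl-linked amide is present; the one step beyond the scatter remains a number 33.2 percentage points higher from compound 1 to compound 2 (beyond the scatter), which lies in another part of the molecule. Nothing given here offers a reason for this result.

From the compounds shown here alone, whether the same substitution would also leave the reading in place on compound 2, which gives 49.6% and has its amide attached directly to the ring, remains open. Also open, going by these compounds, is whether an amine, a hydroxyl or a carboxylic acid on the same aromatic carbon would give a step beyond the scatter, and a single-concentration inhibition reading cannot settle how the potencies of compound 1 and compound 4 compare.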